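Pyridinyl to Carbamate-Bearing Piperidinyl on a Shared Core

The source may report more compounds than this note shows. Statements on the series, on what has been measured and on what is new or still open speak of the compounds shown alone.

Compound 1 `OC1CCN(c2nccnc2OC2CN(c3ccc4ccccc4n3)C2)CC1`: 99000 nM
Compound 2 `c1ccc2nc(N3CC(Oc4nccnc4-c4ccncc4)C3)ccc2c1`: 56000 nM

For the measured compounds named here, in a physicochemical assay for solubility, in phosphate buffer, at pH 7.4 (on this read-out lower numbers stand for lower solubility and higher numbers for higher solubility), compound 2 gives 56000 nM, the lowest of the two numbers so far; its nearest neighbour is compound 1, and the step of a 1.8-fold lower number from compound 1 to compound 2 (0.25 log units; within the scatter) lies within the scatter. Compound 3 `COC(=O)N1CCC(c2nccnc2OC2CN(c3ccc4ccccc4n3)C2)CC1` has not yet been measured. It differs from compound 2 in one place: 1-(methoxycarbonyl)piperidin-4-yl in place of pyridin-4-yl on an aromatic carbon. Going by the values given here, only one measured step is available to judge this change, namely a 1.8-fold lower number from compound 1 to compound 2 (0.25 log units; within the scatter), and that step did not move the number beyond the scatter; no measured pair exchanges the pyridin-4-yl for the 1-(methoxycarbonyl)piperidin-4-yl group itself. For compound 3 a step of about a 1.2-fold lower number from compound 2 to compound 3 (0.09 log units; within the scatter) in this assay is therefore expected, which is no change beyond the scatter, though with considerable uncertainty. Compound 3 is estimated at 45000 nM, with a range from 15000 nM to 130000 nM.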

Compound 3, solubility: 138000 nM
Compound 3: the middle estimate sits 3.1-fold (0.49 log units) below what was measured, and the stated range ends below it.
By their numbers in this assay, from the lowest: compounds 2, 1 and 3 (each within the scatter of the next, the first and the last beyond it).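

In this assay the exchange of pyridin-4-yl for 1-(methoxycarbonyl)piperidin-4-yl gives a 2.5-fold higher number from compound 2 to compound 3 (0.39 log units; beyond the scatter), a modest step, and the first at this position on the aromatic carbon to lie beyond the scatter. The exchange of 4-hydroxypiperidin-1-yl for 1-(methoxycarbonyl)piperidin-4-yl gives only a 1.4-fold higher number from compound 1 to compound 3 (0.14 log units; within the scatter), so among these three compounds just the pair at the two ends of the order separates. No measurement to hand speaks to what lies behind this step.

On these data alone, it stays open whether the step goes with the loss of the aromatic ring or with the methoxycarbonyl group. A piperidin-4-yl carrying a free amine, or a phenyl group on the same carbon, would help to tell these two apart.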